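Swapping the Side Chain of a Cathepsin S Nitrile Inhibitor

A few compounds are considered here, and "the series" means these few. Any claim that something is new, unique, unknown or untested is made for them only; others in the source may bear on it.

Measured compounds:
Compound 1 `N#C[C@@]1(NC(=O)[C@@H](CC(=O)N2CCOCC2)CC2CCC(c3ccccc3)CC2)CCN(C2CCCCC2)C1` – "not determined" (no result reported) in an assay on isolated protein for inhibition of cathepsin S (Homo sapiens); on this read-out lower numbers stand for tighter binding and higher numbers for weaker binding.
Compound 2 `N#C[C@@]1(NC(=O)[C@@H](CC(=O)N2CCOCC2)CC2CCCCC2)CCN(C2CCCC2)C1` – "not determined" (no result reported).
Compound 3 `N#C[C@H](COCc1ccccc1)NC(=O)[C@@H](CC(=O)N1CCOCC1)CC1CCCCC1` – 4.39 nM.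

Compound 1 stands without a number: no dissociation constant was obtained for it, and the same holds for compound 2, so only compound 3 carries a measured value. Compound 4 `N#C[C@@]1(NC(=O)[C@@H](CC(=O)N2CCOCC2)CC2Cc3ccccc3C2)CCN(C2CCCCC2)C1` differs from compound 1 in one place: 2,3-dihydro-1H-inden-2-yl in place of 4-phenylcyclohexyl on a saturated chain carbon, two bonds along the chain from a carbonyl carbon. Among the measured compounds shown here, no measured pair shares this change, so its size is unknown; in this assay a modest shift in either direction, or none beyond the usual scatter, seems plausible. For the measured compounds named here, the only anchor is compound 3 giving 4.39 nM on a related but different core. Compound 4 is estimated to give 10 nM in this assay, with an expected range of 2 nM to 60 nM.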

Compound 4, dissociation constant: 23.1 nM
Beside the measured number, compound 4's estimate is 2.3-fold (0.36 log units) below it, and the stated range covers the measured number.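

No step can be read between compound 1 and compound 4: compound 1 has no single number in this assay. The compounds shown leave open how swapping 4-phenylcyclohexyl for 2,3-dihydro-1H-inden-2-yl shifts binding, and no evidence bears on this result.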